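Trifluoromethoxy in Place of Methyl on a Sulfonyl Aryl Ring

The source may hold more compounds than are shown below. What is called first, only, known or untested is meant among the compounds shown, and "the series" means these compounds.

Among the measured compounds shown here, compound 2 `Cc1ccc(S(=O)(=O)N(C)c2ccc3[nH]c(-c4n[nH]c5ccccc45)cc3n2)cc1` is one of only two compounds measured in a functional assay on HCT-116 cells (Homo sapiens) for antiproliferative activity, read by MTT assay, with a stated time of 72 h; on this read-out higher numbers stand for weaker inhibition and lower numbers for stronger inhibition; in that assay compound 2 gives 13300 nM. For the measured compounds named here, its sole measured neighbour is compound 1 `CN(C(=O)c1ccc(Cl)cc1)c1ccc2[nH]c(-c3n[nH]c4ccccc34)cc2n1`, and in this assay compound 1 gives 3000 nM. Going by the values given here, the single recorded step, a 4.4-fold higher number from compound 1 to compound 2 (0.65 log units; beyond the scatter), exchanges the whole group attached to the ring nitrogen, and leaves compound 2 standing at the higher, weaker end of the pair. Compound 3 `CN(c1ccc2[nH]c(-c3n[nH]c4ccccc34)cc2n1)S(=O)(=O)c1ccc(OC(F)(F)F)cc1` keeps the sulfonyl attachment of compound 2 and alters one substituent on its aryl ring: trifluoromethoxy in place of methyl on an aromatic carbon. Among the compounds with values here, no measured step touches this position, so the data give no guide to the size or direction of the change to expect in this assay. The working expectation for compound 3 is therefore a number close to that of compound 2, with an estimated step of a 1.1-fold lower number from compound 2 to compound 3 (0.04 log units; within the scatter). Compound 3 is accordingly estimated at 12000 nM, within a range of 4000 nM to 40000 nM.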

Compound 3, half-maximal inhibitory concentration: 6040 nM
Estimate against measurement, compound 3: 2.0-fold (0.30 log units) above; the measured number falls inside the stated range.
By their numbers in this assay, from the lowest: compounds 1 and 3 (each within the scatter of the next); then compound 2.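

The substituent on the aryl ring of the sulfonyl group matters in this assay. Trifluoromethoxy in place of methyl gives a 2.2-fold lower number from compound 2 to compound 3 (0.34 log units; beyond the scatter), so a change at this single position moves the number beyond the scatter, whereas the earlier step exchanged the whole group on the ring nitrogen. No measurement shown here bears on the cause of this step.

One pair cannot show whether other groups at this position, such as an amine, a carboxylic acid or a longer chain, would lower the number further, leave it unchanged or raise it. It also cannot show whether trifluoromethoxy would give a step of similar size on the aryl ring of a carbonyl compound such as compound 1.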